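A Benzyl Group on the Amide-Type Nitrogen of Compound 3

The source may report more compounds than this note shows. Statements on the series, on what has been measured and on what is new or still open speak of the compounds shown alone.

Three compounds share one core and were measured in a functional assay on L1210 cells (Mus musculus), with a stated time of 48 h; a lower number here means a stronger inhibitor, a higher number a weaker inhibitor:

Compound 1, `O=C1Nc2ccc(Cl)cc2/C1=N/NC(=S)Nc1ccc(Cl)cc1`, gives 108000 nM.
Compound 2, `O=C1Nc2ccc(Br)cc2/C1=N/NC(=S)Nc1ccc(Cl)cc1`, gives 88000 nM.
Compound 3, `O=C1Nc2ccc(F)cc2/C1=N/NC(=S)Nc1ccc(Cl)cc1`, gives 34000 nM.

Compound 3 stands lowest of the three. The steps to it are a 3.2-fold lower number from compound 1 to compound 3 (0.50 log units; beyond the scatter) and a 2.6-fold lower number from compound 2 to compound 3 (0.41 log units; beyond the scatter), both modest; between the other two, a 1.2-fold lower number from compound 1 to compound 2 (0.09 log units; within the scatter).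

Compound 4, `O=C1/C(=N\NC(=S)Nc2ccc(Cl)cc2)c2cc(F)ccc2N1Cc1ccc(F)cc1`, differs from compound 3 in one place: 4-fluorobenzyl in place of hydrogen on an amide-type nitrogen in a ring. Among the measured compounds shown here, every measured step swaps one halogen for another on an aromatic carbon; none touches the amide-type nitrogen, so no measured step bears directly on this change. What the three steps do show is that even the largest of them, a 3.2-fold lower number from compound 1 to compound 3 (0.50 log units; beyond the scatter), stays modest, and nothing in hand argues for a large move in either direction. The estimate for compound 4 in this assay is 30000 nM. For compound 4 the expected range runs from 6000 nM to 150000 nM. The step this estimate means, a 1.1-fold lower number from compound 3 to compound 4 (0.05 log units; within the scatter), is expected to lie within the scatter, with wide uncertainty.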

Compound 4, half-maximal inhibitory concentration: 154000 nM
Estimate against measurement, compound 4: 5.1-fold (0.71 log units) below; measured number outside the range, above it.
By their numbers in this assay, from the lowest: compound 3; then compounds 2, 1 and 4 (each within the scatter of the next).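

On the amide-type nitrogen in the ring, replacing the hydrogen with 4-fluorobenzyl gives in this assay a step of a 4.5-fold higher number from compound 3 to compound 4 (0.66 log units; beyond the scatter), which makes compound 4 a weaker inhibitor. The earlier steps shown here only exchanged halogens on an aromatic carbon, whereas this one shows that the read-out also responds to what sits on this nitrogen, and that this added group does not give a stronger inhibitor. Nothing available explains the rise.

The compounds shown leave open whether the rise follows from losing the amide hydrogen or is specific to 4-fluorobenzyl, a question that a methyl, a plain benzyl or a longer chain ending in an amine on this nitrogen could help to settle. Also open, as far as these compounds go, is whether 4-fluorobenzyl has the same effect with chloro or bromo in place of the fluoro on the shared core.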